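The source may report more compounds than this note shows. Statements on the series, on what has been measured and on what is new or still open speak of the compounds shown alone.

Measured in a functional assay on HeLa cells (Homo sapiens) for cytotoxicity, read by cell counting, with a stated time of 48 h; on this read-out lower numbers stand for an effect already at smaller amounts and higher numbers for an effect only at larger amounts of compound:
compound 1 `CCCCCCCCCC(=O)O[C@H]1[C@H](O)[C@H](n2ccc(N)nc2=O)O[C@@H]1CO`: 0.09 ug/mL
compound 3 `CCCCCCCCCC(=O)OC[C@H]1O[C@@H](n2ccc(N)nc2=O)[C@@H](O)[C@@H]1OC(=O)CCCCCCCCC`: 0.11 ug/mL
compound 2 `CCCCCCCC/C=C\CCCCCCCC(=O)OC[C@H]1O[C@@H](n2ccc(N)nc2=O)[C@@H](O)[C@@H]1OC(=O)CCCCCCC/C=C\CCCCCCCC`: 1.1 ug/mL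

Compound 1 holds the lowest of the three numbers. Its nearest neighbour is compound 3, reached by a 1.2-fold higher number from compound 1 to compound 3 (0.09 log units; within the scatter), a step within the scatter. Among the measured compounds shown here, compound 2 shows a clearly higher number than compound 1, but the two differ in more than one place, so no single step links them. Compound 4 `CCCCCCCC(=O)O[C@H]1[C@H](O)[C@H](n2ccc(N)nc2=O)O[C@@H]1CO` differs from compound 1 by hydrogen in place of ethyl on a saturated chain carbon, seven bonds along the chain from a carbonyl carbon. For the measured compounds named here, none of the measured steps concerns this change; the only single step seen, a 1.2-fold higher number from compound 1 to compound 3 (0.09 log units; within the scatter), alters a different position and stays within the scatter. Compound 4 is therefore expected to show a step of a 1.7-fold higher number from compound 1 to compound 4 (0.22 log units; within the scatter), not beyond the scatter. The expected value of compound 4 is 0.15 ug/mL, estimated between 0.05 ug/mL and 0.5 ug/mL.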

Compound 4, concentration for half-maximal effect: 0.1 ug/mL
For compound 4 the middle estimate is 1.5-fold (0.18 log units) above the measured one, and the stated range covers the measured number.
By their numbers in this assay, from the lowest: compounds 1, 4 and 3 (each within the scatter of the next); then compound 2.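

In this assay, hydrogen in place of ethyl on a saturated chain carbon, seven bonds along the chain from a carbonyl carbon, gives a 1.1-fold higher number from compound 1 to compound 4 (0.05 log units; within the scatter) and so leaves the number within the scatter. Among the compounds shown here, this is the first step seen at this position, and it shows that the read-out tolerates this loss of ethyl from the chain. No measured evidence bears on this result. The compounds shown leave open whether a longer chain, or an amine or a carboxylic acid at this place, would hold the number or shift it.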